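A few compounds are considered here, and "the series" means these few. Any claim that something is new, unique, unknown or untested is made for them only; others in the source may bear on it.

Measured so far:
Compound 1 `CCN1C(=O)C(O)(Cc2nnn[nH]2)c2cc(Cl)ccc21`: 21500 nM
Compound 2 `CCN1C(=O)C(O)(Cc2nnn[nH]2)c2cc(Br)ccc21`: > 100000 nM

In a functional assay on DU-145 cells (Homo sapiens) for antiproliferative activity, read by MTT assay, with a stated time of 48 h (a lower number here means a stronger inhibitor, a higher number a weaker inhibitor), compound 1 gives 21500 nM. Compound 2 stands at the limit of > 100000 nM in this assay, at which 1 of the 2 values shown sits, which is a limit of the assay and not a number. Its true value is therefore not known.

Compound 3, `CCN1C(=O)C(O)(Cc2nnn[nH]2)c2cc(C)ccc21`, is the next to consider. It carries methyl in place of bromo on an aromatic carbon, the same carbon that differs between the two measured compounds: methyl in place of bromo on an aromatic carbon.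

Among the compounds with values here, only one measured step bears on this change. Swapping chloro for bromo gives an at least 4.6-fold higher number from compound 1 to compound 2 (0.66 log units; beyond the scatter), which is beyond the scatter and shows that the group at this carbon can matter in this assay. Within the data shown here, no compound with methyl has been measured, so this step is only a loose guide. With that single step from compound 1 as the basis, a move back towards a lower number is expected once bromo leaves, though compound 3 may stay weak. The expected change is an at least 2.2-fold lower number from compound 2 to compound 3 (0.34 log units; beyond the scatter). For compound 3 the estimated value is 45000 nM, with an expected range from 15000 nM to 100000 nM.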

Compound 3, half-maximal inhibitory concentration: 14600 nM
For compound 3 the middle estimate is 3.1-fold (0.49 log units) above the measured one; measured number outside the range, below it.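

In this assay, putting methyl on this aromatic carbon in place of bromo brings the reading back into the measurable range, with an at least 6.8-fold lower number from compound 2 to compound 3 (0.83 log units; beyond the scatter). Compound 2 stands at a limit of the assay and not at a number, so this step has a minimum size but no exact size: the limit of > 100000 nM in this assay, at which 1 of the 3 values shown sits.

Set against chloro, methyl gives a 1.5-fold lower number from compound 1 to compound 3 (0.17 log units; within the scatter), so the chloro and methyl versions cannot be told apart here, and among the three groups only bromo stands apart, with its steps to both others lying beyond the scatter.

Still open, going by these compounds, is how other groups on this same carbon would read, such as fluoro, methoxy, an amine, a carboxylic acid or a chain longer than methyl, and whether any of them would give a clearly lower number than chloro and methyl. On these data alone, with three groups at a single position on one shared core, no general trend across substituents can be drawn, and how far compound 2 really lies from the other two remains unknown.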